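Series notes: benzoyl in place of carbamoyl on compound 2

The compounds below may be only part of what the source reports. "The series", "measured", "known", "first", "only" and "open" are said of these compounds alone.

Measured compounds:
Compound 1 `O=CN1CCN(c2ccc(Cl)cc2)C1=S`: in a functional assay on BT-549 cells (Homo sapiens) for inhibition, read by sulforhodamine B assay, with a stated time of 48 h (a higher number here means a weaker inhibitor of growth, a lower number a stronger inhibitor of growth), compound 1 gives 25400 nM.
Compound 2 `N#C/C(=C\N1CCN(C(=O)c2ccco2)C1=S)C(N)=O`: in this assay compound 2 gives 22500 nM.
Compound 3 `O=CN1CCN(c2ccc(Cl)c(Cl)c2)C1=S`: in this assay compound 3 gives 18000 nM.

Compound 2 holds the second highest of the three numbers, and both its neighbours lie within the scatter of it. Among the measured compounds shown here, the only step between compounds that differ in one place, a 1.4-fold lower number from compound 1 to compound 3 (0.15 log units; within the scatter), is within the scatter.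

Compound 4 `N#C/C(=C\N1CCN(C(=O)c2ccco2)C1=S)C(=O)c1ccccc1` differs from compound 2 in one place: phenyl in place of amino on a carbonyl carbon. For the measured compounds named here, no measured step touches this position; the one step on record concerns chloro on an aromatic carbon of the other core and does not bear on a change at the carbonyl carbon. With nothing to guide it, the number for compound 4 is expected to stay close to that of compound 2, with no step beyond the scatter. Compound 4 is estimated at 16000 nM, expected between 4000 nM and 60000 nM. The estimate corresponds to an expected step of a 1.4-fold lower number from compound 2 to compound 4 (0.15 log units; within the scatter).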

Compound 4, concentration for 50% growth inhibition: 7800 nM
For compound 4 the middle estimate is 2.1-fold (0.31 log units) above the measured one; measured number inside the range.
By their numbers in this assay, from the lowest: compound 4; then compounds 3, 2 and 1 (each within the scatter of the next).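

Phenyl in place of amino on the carbonyl carbon gives, in this assay, a 2.9-fold lower number from compound 2 to compound 4 (0.46 log units; beyond the scatter), a modest step and the only one in the series beyond the scatter, so this position does alter the read-out. The change removes a hydrogen-bond donor and adds an aromatic ring at once, and the two cannot be separated here. Nothing measured here accounts for the step.

From the compounds shown here alone, it remains open whether the aromatic ring or the loss of amino matters more. A methyl group, a longer alkyl chain or a dimethylamino group on the carbonyl carbon would help to separate them.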